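The source may report more compounds than this note shows. Statements on the series, on what has been measured and on what is new or still open speak of the compounds shown alone.

In a functional assay, read by fluorescence and spectrophotometry, with a stated time of 1 h (on this read-out lower numbers stand for an effect already at smaller amounts and higher numbers for an effect only at larger amounts of compound), compound 1 `O=S(=O)(/C=C/c1ccc(O)c(O)c1)CCC1CCCCC1` gives 9800 nM, and compound 2 `CCCCCCCS(=O)(=O)/C=C/c1ccc(O)c(O)c1` gives 7100 nM. Among the compounds with values here, these are the only two numbers so far, and compound 2 stands within the scatter of compound 1, so the pair cannot be ranked. Compound 3 `O=S(=O)(/C=C/c1ccc(O)c(O)c1)CCCc1ccccc1` keeps the core of compound 2 but alters its chain: phenyl in place of butyl on a saturated chain carbon, three bonds along the chain from a sulfonyl sulfur. The same difference can also be read as pentyl to benzyl. Within the data shown here, only one measured step bears on this change. It also exchanges a ring and an open chain, with pentyl in place of cyclohexyl: a 1.4-fold lower number from compound 1 to compound 2 (0.14 log units; within the scatter). That ring was saturated, whereas the incoming phenyl is aromatic, so the guide is only partial. No shift beyond the scatter is therefore expected in this assay. The expected change is a 1.1-fold higher number from compound 2 to compound 3 (0.05 log units; within the scatter). The estimate for compound 3 is 8000 nM, with an expected range of 3000 nM to 20000 nM.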

Compound 3, half-maximal effective concentration: 11500 nM
Compound 3: middle estimate off by 1.4-fold (0.16 log units), on the low side; low and high end bracket the measured number.
By their numbers in this assay, from the lowest: compounds 2, 1 and 3 (each within the scatter of the next).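

In this assay, a 1.6-fold higher number from compound 2 to compound 3 (0.21 log units; within the scatter), and a 1.2-fold higher number from compound 1 to compound 3 (0.07 log units; within the scatter), so neither step can be told apart from the scatter. Together with the earlier step, this means that an open chain, a saturated ring and an aromatic ring at the end of the chain give numbers that cannot be ranked across these three compounds, and none of the three goes against this. Nothing shown here explains why these groups read alike.

From the compounds shown here alone, all three groups at this place are built of carbon only, so what an amine or a carboxylic acid at the end of the chain would do remains open. Going by these compounds, a much longer chain is equally open, as is whether changes to the shared core would shift the number beyond the scatter.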